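Compound 4, an Aminophenyl Urea After Three Inactive Analogues

A few compounds are considered here, and "the series" means these few. Any claim that something is new, unique, unknown or untested is made for them only; others in the source may bear on it.

Compound 1 `Cc1cc(NC(=O)Nc2ncccc2C)c2ccccc2n1`, compound 2 `Cc1cc(NC(=O)Nc2ccc(F)cc2)c2ccccc2n1` and compound 3 `Cc1cc(NC(=O)Nc2ccc(Cl)cc2)c2ccccc2n1` share one core and differ only in the group on the amide-type nitrogen. In an ADME assay on HEK293 cells (Homo sapiens) for cytotoxicity, with a stated time of 72 h (on this read-out lower numbers stand for an effect already at smaller amounts and higher numbers for an effect only at larger amounts of compound), compound 1 gives only a limit, > 25000 nM. In this assay compound 2 likewise reaches only a limit, > 25000 nM. Compound 3 also stands at a limit, > 25000 nM. All three thus sit at the limit of > 25000 nM in this assay, at which 3 of the 3 values shown sit, and the steps a step that the two limits leave unreadable from compound 1 to compound 3 and a step that the two limits leave unreadable from compound 2 to compound 3 cannot be sized. Compound 4 `Cc1cc(NC(=O)Nc2ccccc2N)c2ccccc2n1` brings (2-aminophenyl in place of 4-chlorophenyl on an amide-type nitrogen). Within the data shown here, no measured step reads on this change, and nothing beyond the scatter is indicated, so the step expected is a step that the limit leaves unreadable from compound 3 to compound 4. Compound 4 is therefore estimated at about 30000 nM in this assay, within 8000 nM to 100000 nM.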

Compound 4, half-maximal effective concentration: > 25000 nM
Compound 4 gave a limit, no number; the forecaster's own chance of this, stated with the estimate: 80%; the middle value does not contradict the limit.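

In this assay compound 4 also gives only a limit, > 25000 nM, so no step between compound 4 and compound 1, compound 2 or compound 3 can be read: the limit of > 25000 nM in this assay, at which 4 of the 4 values shown sit.

The compounds shown leave open whether any of these groups on the amide-type nitrogen changes the cytotoxicity read-out at all.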